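Working notes: swapping the aryl group on the nitrogen

The compounds below may be only part of what the source reports. "The series", "measured", "known", "first", "only" and "open" are said of these compounds alone.

Measured so far in a functional assay on OVCAR-8 cells (Homo sapiens) for inhibition, read by sulforhodamine B assay, with a stated time of 48 h; a higher number here means a weaker inhibitor of growth, a lower number a stronger inhibitor of growth
- compound 1 `CN1CCN(CCCOc2cccc3nc(Nc4ccc(Cl)c(C(F)(F)F)c4)ccc23)CC1` gives 1920 nM
- compound 2 `CC(C)c1ccc(Nc2ccc3c(OCCCN4CCN(C)CC4)cccc3n2)cc1` gives 17800 nM
- compound 3 `CN1CCN(CCCOc2cccc3nc(Nc4ccc(F)c(F)c4)ccc23)CC1` gives 5130 nM

Compound 3 at 5130 nM is the second highest of the three numbers, with compound 1 lower and compound 2 higher, each gap beyond the scatter. Compound 4 `CN1CCN(CCCOc2cccc3nc(Nc4cccc(Cl)c4)ccc23)CC1` is not yet measured. It carries 3-chlorophenyl in place of 3,4-difluorophenyl on a nitrogen on an aromatic ring.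

Among the measured compounds shown here, no measured step makes this exact exchange, but all three alter the group on that nitrogen. The step of a 9.3-fold higher number from compound 1 to compound 2 (0.97 log units; beyond the scatter) spans the whole range, while a 2.7-fold higher number from compound 1 to compound 3 (0.43 log units; beyond the scatter) and a 3.5-fold lower number from compound 2 to compound 3 (0.54 log units; beyond the scatter) are smaller. The entering group shares chlorine with the group of compound 1 at 1920 nM but has no trifluoromethyl. A slight lean toward a lower number is therefore expected in this assay but no step beyond the scatter. The expected step is a 1.4-fold lower number from compound 3 to compound 4 (0.13 log units; within the scatter) and would leave the two values hard to separate. For compound 4 the estimated value is 3800 nM within an expected range (1700 nM to 8500 nM).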

Compound 4, concentration for 50% growth inhibition: 1900 nM
Compound 4: middle estimate off by 2.0-fold (0.30 log units), on the high side, within the range that was stated.
By their numbers in this assay, from the lowest: compounds 4 and 1 (each within the scatter of the next); then compound 3; then compound 2.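

In this assay, 3-chlorophenyl on the nitrogen gives a 2.7-fold lower number from compound 3 to compound 4 (0.43 log units; beyond the scatter) and a 9.4-fold lower number from compound 2 to compound 4 (0.97 log units; beyond the scatter) so a group carrying one chlorine and no fluorine stands clearly apart from both 3,4-difluorophenyl and 4-isopropylphenyl. The step of a 1.0-fold lower number from compound 1 to compound 4 (0.00 log units; within the scatter) cannot be told from the scatter, which shows that the trifluoromethyl of 4-chloro-3-(trifluoromethyl)phenyl is not required to reach the level of compound 1 in this series. Across these four compounds, the two groups with chlorine sit together at the low end with no compound going against that grouping, but no independent measurement bears on why the groups fall in this order.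

As far as these compounds go, whether the chlorine itself matters stays open, and a bare phenyl, or a bromine or a methyl in place of the chlorine of 3-chlorophenyl, would bear on that question. From the compounds shown here alone, all four compounds share everything outside the group on the nitrogen, so the effect of changes elsewhere, such as a longer chain, a different amine or a carboxylic acid, remains unknown.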